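Side-chain swap on the shared core: amide to pyrrolidinylmethyl

A few compounds are considered here, and "the series" means these few. Any claim that something is new, unique, unknown or untested is made for them only; others in the source may bear on it.

Compound 1 `CNC(=O)C[C@@H]1C[C@@H](c2ccc(Cl)c(Cl)c2)[C@H](NC(=O)c2cc(-c3c(Cl)cnn3C)c(Cl)o2)CN1` carries a methylcarbamoyl group on the saturated chain carbon bound to a saturated ring carbon of the shared core. In a functional assay on HCT-116 cells (Homo sapiens) for antiproliferative activity, read by sulforhodamine B assay, with a stated time of 72 h (a lower number here means a stronger inhibitor, a higher number a weaker inhibitor), compound 1 gives 450 nM, the lowest of the three numbers in hand. Compound 2 `Cn1ncc(Cl)c1-c1cc(C(=O)N[C@@H]2CN[C@H](CCCO)C[C@H]2c2ccc(Cl)c(Cl)c2)oc1Cl` gives 510 nM, and the step of a 1.1-fold higher number from compound 1 to compound 2 (0.05 log units; within the scatter) shows that exchanging the methylcarbamoyl group for a 2-hydroxyethyl group leaves the number where it was. Compound 3 `Cn1ncc(Cl)c1-c1cc(C(=O)N[C@@H]2CN[C@H](CC(=O)NCC(O)CO)C[C@H]2c2ccc(Cl)c(Cl)c2)oc1Cl` gives 7090 nM; the steps of a 16-fold higher number from compound 1 to compound 3 (1.20 log units; beyond the scatter) and a 14-fold higher number from compound 2 to compound 3 (1.14 log units; beyond the scatter) show that the (2,3-dihydroxypropyl)carbamoyl group at this position costs a large amount.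

Compound 4 `Cn1ncc(Cl)c1-c1cc(C(=O)N[C@@H]2CN[C@H](CCN3CCCC3)C[C@H]2c2ccc(Cl)c(Cl)c2)oc1Cl` differs from compound 1 by (pyrrolidin-1-yl)methyl in place of methylcarbamoyl on a saturated chain carbon bound to a saturated ring carbon. The bearing steps are the two from this position: the neutral exchange to compound 2 and the large loss to compound 3. The entering group resembles neither case closely, so the step of a 1.1-fold higher number from compound 1 to compound 4 (0.05 log units; within the scatter) is expected to stay near the scatter, with the loss seen for compound 3 marking the downside. In this assay compound 4 is estimated at 500 nM, within a range of 150 nM to 1800 nM.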

Compound 4, half-maximal inhibitory concentration: 1940 nM
Compound 4: middle estimate off by 3.9-fold (0.59 log units), on the low side; the measured number lies above the stated range.
By their numbers in this assay, from the lowest: compounds 1 and 2 (each within the scatter of the next); then compound 4; then compound 3.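

In this assay this position, on a saturated chain carbon bound to a saturated ring carbon, no longer looks flat at the upper end: (pyrrolidin-1-yl)methyl in place of methylcarbamoyl gives a measurable loss (a 4.3-fold higher number from compound 1 to compound 4 (0.63 log units; beyond the scatter)), and pyrrolidin-1-yl in place of hydroxymethyl gives one of similar size (a 3.8-fold higher number from compound 2 to compound 4 (0.58 log units; beyond the scatter)), so the match between compound 1 and compound 2 does not extend to every group placed here. The loss also stops short of the one carried by the (2,3-dihydroxypropyl)carbamoyl group (a 3.7-fold lower number from compound 3 to compound 4 (0.56 log units; beyond the scatter)), which leaves three separate levels across the four compounds: compound 1 and compound 2 together, then compound 4, then compound 3. No accompanying data bear on the origin of these differences.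

As far as these compounds go, whether the step follows the ring of the entering group or its nitrogen remains open, and a 2-(dimethylamino)ethyl chain, a 2-(morpholin-4-yl)ethyl chain or a 2-cyclopentylethyl chain would help to separate the two. A carboxylic acid at the chain end, or a longer chain carrying the same pyrrolidine ring, would show how far this range of numbers reaches at the position.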